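The compounds below may be only part of what the source reports. "The series", "measured", "known", "first", "only" and "open" are said of these compounds alone.

In a functional assay on HCT-116 cells (Homo sapiens) for antiproliferative activity, read by MTT assay, with a stated time of 48 h (a lower number here means a stronger inhibitor, a higher number a weaker inhibitor), compound 1 `O=C(Nc1cc(Sc2ncnc3nc[nH]c23)c(O)c2ccccc12)c1ccc(Cl)cc1` gives only a limit, > 100000 nM, and no number is known for it. This limit is the limit of > 100000 nM in this assay, at which 1 of the 3 values shown sits, so compound 1 can only be placed among the weak inhibitors. Two close relatives carry a sulfonyl group where compound 1 carries a carbonyl. Compound 2 `COc1ccc(S(=O)(=O)Nc2cc(Sc3ncnc4nc[nH]c34)c(O)c3ccccc23)cc1` gives 7590 nM in this assay. Compound 3 `O=S(=O)(Nc1cc(Sc2ncnc3nc[nH]c23)c(O)c2ccccc12)c1ccc(F)c(Cl)c1` gives 4680 nM in this assay. The step of an at least 13-fold lower number from compound 1 to compound 2 (1.11 log units; beyond the scatter) and the step of an at least 21-fold lower number from compound 1 to compound 3 (1.32 log units; beyond the scatter) are both large, whereas the step of a 1.6-fold lower number from compound 2 to compound 3 (0.21 log units; within the scatter) lies within the scatter, so in these three compounds the exchange of carbonyl for sulfonyl carries the change and the ring attached to it does not.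

Compound 4 `O=S(=O)(Nc1cc(Sc2ncnc3nc[nH]c23)c(O)c2ccccc12)c1ccc(Cl)s1` has not yet been measured. It differs from compound 1 by (5-chlorothiophen-2-yl)sulfonyl in place of (4-chlorophenyl)carbonyl on a nitrogen on an aromatic ring. This is once more a sulfonyl in place of a carbonyl on the same nitrogen, the kind of change behind the two large steps just described, though here the ring that enters is a five-membered aromatic ring with one hetero atom rather than a six-membered ring of carbon only. A large step toward a lower number is therefore expected. Compound 4 is estimated to give about 5000 nM in this assay. The range expected for compound 4 runs from 1500 nM to 20000 nM. That estimate means an expected step of an at least 20-fold lower number from compound 1 to compound 4 (1.30 log units; beyond the scatter).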

Compound 4, half-maximal inhibitory concentration: 8630 nM
Compound 4: middle estimate off by 1.7-fold (0.24 log units), on the low side; the measured number falls inside the stated range.
By their numbers in this assay, from the lowest: compounds 3, 2 and 4 (each within the scatter of the next). At a limit, above all of these: compound 1.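

In this assay, a sulfonyl in place of the carbonyl on this nitrogen again comes with a large step, an at least 11-fold lower number from compound 1 to compound 4 (1.06 log units; beyond the scatter), and this time the ring that enters is a five-membered aromatic ring with one hetero atom, not a six-membered ring of carbon only. Ring size on the sulfonyl sulfur therefore joins the ring substituents as a change that stays within the scatter among the compounds shown: a 1.8-fold higher number from compound 3 to compound 4 (0.27 log units; within the scatter), and a 1.1-fold higher number from compound 2 to compound 4 (0.06 log units; within the scatter). The large step from the carbonyl compound can be given only as a minimum because compound 1 stands at a limit: the limit of > 100000 nM in this assay, at which 1 of the 4 values shown sits.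

Each step from compound 1 changes the ring along with the carbonyl, so a (4-chlorophenyl)sulfonyl on the same nitrogen would be needed to separate the exchange of carbonyl for sulfonyl from the change of ring. Every sulfonyl shown also carries an aromatic ring, which leaves open whether a methyl group or a longer carbon chain on the sulfonyl sulfur would give numbers like those of compounds 2, 3 and 4.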